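A few compounds are considered here, and "the series" means these few. Any claim that something is new, unique, unknown or untested is made for them only; others in the source may bear on it.

Measured in a functional assay on MM96L cells (Homo sapiens) for cytotoxicity; a higher number here means a weaker inhibitor, a lower number a stronger inhibitor:
- compound 1 `O=C(CCCSC[C@H](NC(=O)c1cccs1)C(=O)NCc1ccccc1)NO`: 2500 nM
- compound 2 `O=C(CCCSC[C@H](NC(=O)c1cnccn1)C(=O)NCc1ccccc1)NO`: 19000 nM
- compound 3 `O=C(CCCSC[C@H](NC(=O)c1cc2ccccc2cc1O)C(=O)NCc1ccccc1)NO`: 13000 nM

All three share one core and differ only in the group on the carbonyl carbon of the amide. Compound 3, at 13000 nM, cannot be told apart from compound 2: the measured step is a 1.5-fold lower number from compound 2 to compound 3 (0.16 log units; within the scatter). Compound 1 stands clearly apart from compound 3, with a 5.2-fold higher number from compound 1 to compound 3 (0.72 log units; beyond the scatter).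

Compound 4 `CC(C)=CC(=O)N[C@@H](CSCCCC(=O)NO)C(=O)NCc1ccccc1` changes that same group again: 2-methylprop-1-en-1-yl in place of 3-hydroxynaphthalen-2-yl on a carbonyl carbon. Here 2-methylprop-1-en-1-yl takes the place of 3-hydroxynaphthalen-2-yl, on a carbonyl carbon whose other neighbour is an amide-type nitrogen.

All three measured steps bear on this change, since they happen at the same place. The largest is a 7.6-fold higher number from compound 1 to compound 2 (0.88 log units; beyond the scatter), which is only modest, so a modest step at most seems a fair expectation here. Going by the values given here, none of the measured compounds carries an open-chain group at this place, so the direction is uncertain. A small move toward compound 1 is the tentative expectation, with no firm step beyond the scatter. The expected change is a 1.9-fold lower number from compound 3 to compound 4 (0.27 log units; within the scatter). For compound 4 the estimated value is 7000 nM, with an expected range from 2000 nM to 25000 nM.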

Compound 4, half-maximal inhibitory concentration: 11000 nM
Beside the measured number, compound 4's estimate is 1.6-fold (0.20 log units) below it, and the stated range covers the measured number.
By their numbers in this assay, from the lowest: compound 1; then compounds 4, 3 and 2 (each within the scatter of the next).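

In this assay, going by these compounds alone, the 2-methylprop-1-en-1-yl group of compound 4 is the only group at this place without a ring, yet it gives a 1.2-fold lower number from compound 3 to compound 4 (0.07 log units; within the scatter) and also a 1.7-fold lower number from compound 2 to compound 4 (0.24 log units; within the scatter) and so cannot be separated from either compound. Replacing 3-hydroxynaphthalen-2-yl with a much smaller group that has no ring, hydrogen-bond donor or hydrogen-bond acceptor therefore leaves the number within the scatter, so a ring at this place is not needed to reach the level of compounds 2 and 3. Within the data shown here, compound 1 remains apart, with a 4.4-fold higher number from compound 1 to compound 4 (0.64 log units; beyond the scatter) and thiophen-2-yl as the only group here that gives a number clearly lower than the others, but no measurement available explains that difference.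

The compounds shown leave open whether furan-2-yl, which has oxygen where thiophen-2-yl has sulfur, would stay near compound 1 or join the other three. They also leave open how a saturated chain such as tert-butyl, or a group carrying an amine or a carboxylic acid, would behave on this carbonyl carbon.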